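Capping the side-chain hydroxy of compound 1

This account rests on a few compounds, and the source may have more. Where it says the series, first, only, none or still open, it means among the compounds named here.

In a functional assay on HT-29 cells (Homo sapiens) for antiproliferative activity, read by MTT assay, with a stated time of 72 h (a higher number here means a weaker inhibitor, a lower number a stronger inhibitor), compound 1 (`COc1cc2c(Oc3ccc(Nc4nccc5[nH]cc(-c6ccc(F)cc6)c(=O)c45)cc3F)ccnc2cc1OCCO`) gives 2900 nM as its reading, compound 2 (`O=c1c(-c2ccc(F)cc2)c[nH]c2ccnc(Nc3ccc(Oc4ccnc5cc(OCCO)ccc45)c(F)c3)c12`) gives 5500 nM in the same test, and compound 3 (`CC(C)(O)COc1ccc2c(Oc3ccc(Nc4nccc5[nH]cc(-c6ccc(F)cc6)c(=O)c45)cc3F)ccnc2c1`) gives 3400 nM there too. These three values lie within the scatter of one another, so compound 1 stands level with its two relatives.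

Compound 4 (`COCCOc1cc2nccc(Oc3ccc(Nc4nccc5[nH]cc(-c6ccc(F)cc6)c(=O)c45)cc3F)c2cc1OC`) alters compound 1 in one place. The difference is methyl in place of hydrogen on an oxygen on a saturated carbon and it turns 2-hydroxyethyl into 2-methoxyethyl, with methyl in place of hydrogen on an oxygen on a saturated carbon.

Among the compounds with values here, no measured step makes this exact change, since all three measured compounds keep the hydroxy. Two steps offer indirect guidance. Hydrogen in place of methoxy on an aromatic carbon gave a 1.9-fold higher number from compound 1 to compound 2 (0.28 log units; within the scatter) and stayed small. The closer guide is a change on the chain itself, where 1-hydroxy-1-methylethyl in place of hydroxymethyl gave a 1.6-fold lower number from compound 2 to compound 3 (0.21 log units; within the scatter) as its result. Neither step left the scatter, so no clear shift is expected in this assay for this small change at the end of the chain, and no direction is favoured with confidence. The estimated step is a 1.2-fold lower number from compound 1 to compound 4 (0.06 log units; within the scatter) and would stay modest. For compound 4 the expected value is 2500 nM with an estimated range from 900 nM to 6500 nM as its span.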

Compound 4, half-maximal inhibitory concentration: 4600 nM
The estimate for compound 4 lay 1.8-fold (0.26 log units) below the measured number; the measured number falls inside the stated range.
By their numbers in this assay, from the lowest: compounds 1, 3, 4 and 2 (each within the scatter of the next).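

Methyl in place of hydrogen on the oxygen at the end of the chain, which turns 2-hydroxyethyl into 2-methoxyethyl, gives a 1.6-fold higher number from compound 1 to compound 4 (0.20 log units; within the scatter) in this assay. The earlier compounds shown here all carried a free hydroxy on the chain, so they could not show what happens when that hydroxy hydrogen is removed; this pair shows that the two forms cannot be told apart in this test, which means that, on the core of compound 1, the free hydroxy is not needed for a reading of this size. Nothing available on these compounds speaks to why the two readings sit so close together.

The compounds shown leave open how much change this end of the chain tolerates, for example whether an amine or a carboxylic acid in place of the hydroxy, or a longer chain carrying the methoxy, would also read level with compound 1. They also leave open whether the same capping would read alike on compound 2, which lacks the ring methoxy, or on compound 3, whose chain is branched.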